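Acetyl for bromine on the aryl ether of a desaturase inhibitor

The source may report more compounds than this note shows. Statements on the series, on what has been measured and on what is new or still open speak of the compounds shown alone.

Compound 1 `Brc1ccccc1OC1CCN(c2ccc(-n3ccnc3)nn2)CC1`: 5 nM
Compound 2 `Cc1ccc(OC2CCN(c3ccc(-n4ccnc4)nn3)CC2)cc1`: 527 nM
Compound 3 `Brc1cccc(OC2CCN(c3ccc(-n4ccnc4)nn3)CC2)c1`: 23 nM

Three analogues sharing one core were measured in an assay on microsomes from liver for inhibition of acyl-CoA desaturase 1 (Rattus norvegicus); on this read-out lower numbers stand for stronger inhibition and higher numbers for weaker inhibition. Compound 3 holds the second highest of the three numbers; its nearest neighbour is compound 1, where the step of a 4.6-fold higher number from compound 1 to compound 3 (0.66 log units; beyond the scatter) is modest, and furthest from it lies compound 2, with the large step of a 23-fold lower number from compound 2 to compound 3 (1.36 log units; beyond the scatter) separating them. Compound 4 `CC(=O)c1ccccc1OC1CCN(c2ccc(-n3ccnc3)nn2)CC1` has not yet been measured; it differs from compound 3 in that (2-acetylphenyl in place of 3-bromophenyl on an oxygen on a saturated carbon).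

Within the data shown here, two measured steps bear on this change. The step of a 4.6-fold higher number from compound 1 to compound 3 (0.66 log units; beyond the scatter) shows that moving a bromine from the 2-bromophenyl to the 3-bromophenyl costs a modest amount, so a return to a 2-substituted ring in compound 4 points toward a lower number. The step of a 23-fold lower number from compound 2 to compound 3 (1.36 log units; beyond the scatter) shows that the identity of the substituent itself can move the number a long way, and no acetyl group has been tested here. The estimate for compound 4 is therefore a step of a 1.5-fold lower number from compound 3 to compound 4 (0.19 log units; within the scatter) toward a lower number, held with wide uncertainty. Compound 4 is expected to give about 15 nM, in the range 3 nM to 90 nM.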

Compound 4, half-maximal inhibitory concentration: 34 nM
Beside the measured number, compound 4's estimate is 2.3-fold (0.36 log units) below it; measured number inside the range.
By their numbers in this assay, from the lowest: compound 1; then compounds 3 and 4 (each within the scatter of the next); then compound 2.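

Among these compounds, with the ring place held and only the group exchanged, acetyl for bromo on an aromatic carbon gives in this assay a 6.8-fold higher number from compound 1 to compound 4 (0.83 log units; beyond the scatter) and thus shows what the earlier compounds could not: a group on the ring in the 2-acetylphenyl arrangement does not by itself retain the number of the 2-bromophenyl ether in compound 1. The acetyl compound nevertheless keeps a clear lead over the 4-methylphenyl ether, with a 16-fold lower number from compound 2 to compound 4 (1.19 log units; beyond the scatter) on this read-out, while a 1.5-fold higher number from compound 3 to compound 4 (0.17 log units; within the scatter) places it level with the 3-bromophenyl ether, so in this set of four the 2-bromophenyl ether alone has the lowest number. Nothing shown here gives a reason for the difference between bromo and acetyl.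

Going by these compounds, whether compound 1 owes its number to bromine in particular remains open, and a 2-chlorophenyl, 2-methylphenyl or 2-methoxyphenyl ether would show where other groups fall relative to compound 1 and compound 4. A 3-acetylphenyl or 4-bromophenyl ether would also be needed to separate the place of the group from its kind, since the 4-methylphenyl ether of compound 2 changes both at once.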